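This account rests on a few compounds, and the source may have more. Where it says the series, first, only, none or still open, it means among the compounds named here.

Working notes on the series in a functional assay on HO8910 cells (Homo sapiens) for inhibition, read by MTT assay, with a stated time of 24 h, tested at 1 ug/mL; a lower number here means less inhibition of growth, a higher number more inhibition of growth at the concentration tested. Compound 1 (`CC(=O)SCCC(CCCCC(=O)O)SC(C)=O`) gives "not active" (no number reported), so it has no single number to serve as a starting point. Compound 3 (`O=C(CCCCC1CCSS1)Nc1ccccn1`) likewise gives "not active" (no number reported). Among the compounds with values here, compound 2 (`O=C(CCCCC1CCSS1)Nc1ccccc1Cl`) is the only one of the measured compounds with a number, at 7.74%.

Compound 4 (`CC(=O)SCCC(CCCCC(=O)Nc1ccc(Cl)cc1)SC(C)=O`) differs from compound 1 in one place: (4-chlorophenyl)amino in place of hydroxy on a carbonyl carbon. In words, (4-chlorophenyl)amino stands in place of hydroxy on a carbonyl carbon, and the acid of compound 1 becomes an amide bearing one six-membered aromatic ring of carbon only.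

Within the data shown here, no measured pair differs in one place, so no step can be carried over, and the expectation rests on thin evidence. In this assay a small upward step is expected, probably not far beyond the usual scatter. The amide compound 2 gives only 7.74%, and the amide compound 3 goes against any gain from an amide, with "not active" (no number reported). A result of no activity for compound 4 remains quite possible.

For compound 4 the estimated value is 10%, with an expected range of 0% to 30%.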

Compound 4, percent growth inhibition at one concentration: 0.35%
Compound 4: middle estimate off by 9.7 percentage points, on the high side; the measured number falls inside the stated range.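

No step can be read from compound 1 to compound 4: in this assay compound 1 gives "not active" (no number reported), with no single number, while compound 4 gives 0.35% at the one concentration tested. The compounds shown leave open whether (4-chlorophenyl)amino in place of hydroxy changes growth inhibition at all. No measurement shown bears on the cause of this result.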